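The source may report more compounds than this note shows. Statements on the series, on what has been measured and on what is new or still open speak of the compounds shown alone.

Three compounds have been measured in a functional assay on MCF7 cells (Homo sapiens) for cytotoxicity, read by MTT assay, with a stated time of 24 h, tested at 6.4 ug/mL; a higher number here means a stronger effect of the compound at the concentration tested, a lower number a weaker effect:

compound 1, `Cn1c(-c2ccc(NC(=O)CCl)cc2)nc(-c2ccccc2)c1-c1ccccc1`, gives 14.2%
compound 2, `Cc1ccc2oc(SCC(=O)Nc3ccc(-c4nc(-c5ccccc5)c(-c5ccccc5)n4C)cc3)nc2c1`, gives 24.6%
compound 3, `Cn1cnnc1SCC(=O)Nc1ccc(-c2nc(-c3ccccc3)c(-c3ccccc3)n2C)cc1`, gives 59.2%

Compound 3 stands highest of the three. Its nearest neighbour is compound 2, and the step of a number 34.6 percentage points higher from compound 2 to compound 3 (beyond the scatter); its furthest is compound 1, with the step of a number 45 percentage points higher from compound 1 to compound 3 (beyond the scatter). The smaller step of a number 10.4 percentage points higher from compound 1 to compound 2 (beyond the scatter) completes the set. Within this small group, replacing the chloro on the saturated chain carbon with a sulfanyl-linked heteroaryl raised the read-out, and the triazolyl on the sulfur gave the larger rise.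

Compound 4, `Cn1nnnc1SCC(=O)Nc1ccc(-c2nc(-c3ccccc3)c(-c3ccccc3)n2C)cc1`, has not been measured. It differs from compound 3 in one place: 1-methyl-1H-tetrazol-5-yl in place of 4-methyl-4H-1,2,4-triazol-3-yl on a sulfur. Among the measured compounds shown here, the only measured step that touches the group on the sulfur is the one from compound 2 to compound 3, which was large, but it exchanged a bicyclic ring for a five-membered one, whereas here one five-membered aromatic ring gives way to another of the same size. For the measured compounds named here, no measured pair shows a change of this kind, so the expected step of a number 7.2 percentage points lower from compound 3 to compound 4 (within the scatter) is one that need not go beyond the scatter, in either direction. Compound 4 is therefore expected to give about 52%, within a range of 32% to 72%.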

Compound 4, a percentage reported as activity, at one concentration (the size of the read-out at that concentration, not a potency): 55.9%
Estimate against measurement, compound 4: 3.9 percentage points below, within the range that was stated.
By their numbers in this assay, from the lowest: compound 1; then compound 2; then compounds 4 and 3 (each within the scatter of the next).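

In this assay, 1-methyl-1H-tetrazol-5-yl in place of 4-methyl-4H-1,2,4-triazol-3-yl on the sulfur gives a step of a number 3.3 percentage points lower from compound 3 to compound 4 (within the scatter), so this position tolerated a fourth hetero atom in the five-membered aromatic ring without a change that could be told from the scatter. The large rise seen earlier is thus not confined to the triazolyl group: the tetrazolyl group gives a number 31.3 percentage points higher from compound 2 to compound 4 (beyond the scatter) against the 5-methyl-1,3-benzoxazol-2-yl group and a number 41.7 percentage points higher from compound 1 to compound 4 (beyond the scatter) against the chloro group, while compound 2 shows that a sulfanyl-linked ring alone does not secure so large a rise. Nothing available bears on what lies behind these differences.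

The compounds shown leave open whether the read-out at this position needs an aromatic ring on the sulfur at all, as a simple amine or a carboxylic acid in place of the sulfanyl-linked ring would show. They also leave open whether the methyl on the ring matters, and whether a longer chain between the sulfur and the carbonyl would keep the read-out of compound 3 and compound 4.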